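Compound 3 to compound 4: methoxy in place of chloro

The compounds below may be only part of what the source reports. "The series", "measured", "known", "first", "only" and "open" are said of these compounds alone.

In a functional assay on HepG2 cells (Homo sapiens) for antiproliferative activity, read by MTT assay, with a stated time of 72 h (on this read-out higher numbers stand for weaker inhibition and lower numbers for stronger inhibition), compound 3 (`O=C1COc2ccc(-c3cnc(Cl)c(NS(=O)(=O)c4ccc(F)cc4)c3)cc2N1c1ccc(Cl)cc1`) gives 33900 nM, within the scatter of compound 1 (`COc1ncc(-c2ccc3c(c2)N(c2ccc(C)cc2)C(=O)CO3)cc1NS(=O)(=O)c1ccc(F)cc1`) at 28300 nM. Compound 2 (`COc1ncc(-c2ccc3c(c2)N(C2CCCCC2)C(=O)CO3)cc1NS(=O)(=O)c1ccc(F)cc1`) gives only a limit of the assay, > 40000 nM.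

Compound 4 (`COc1ncc(-c2ccc3c(c2)N(c2ccc(Cl)cc2)C(=O)CO3)cc1NS(=O)(=O)c1ccc(F)cc1`) has methoxy in place of chloro on an aromatic carbon. Among the compounds with values here, the one measured step, an at least 1.4-fold higher number from compound 1 to compound 2 (0.15 log units; that floor lies within the scatter), is cyclohexyl in place of 4-methylphenyl on an amide-type nitrogen in a ring, so it gives no size for this change. Compound 1 already carries the methoxy and gives 28300 nM, so no step beyond the scatter is expected in this assay. The expected step is a 1.1-fold lower number from compound 3 to compound 4 (0.05 log units; within the scatter). For compound 4 the estimated value is 30000 nM, with an expected range of 14000 nM to 55000 nM.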

Compound 4, half-maximal inhibitory concentration: 17900 nM
Compound 4: middle estimate off by 1.7-fold (0.22 log units), on the high side; the range from low to high includes it.
By their numbers in this assay, from the lowest: compounds 4, 1 and 3 (each within the scatter of the next). At a limit, above all of these: compound 2.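

Methoxy against chloro on the aromatic carbon next to the ring nitrogen now has a direct reading in this assay: a 1.9-fold lower number from compound 3 to compound 4 (0.28 log units; within the scatter), so this change has no effect that can be told from the scatter. On the aryl group at the amide-type nitrogen, chloro in place of methyl gives a 1.6-fold lower number from compound 1 to compound 4 (0.20 log units; within the scatter), again inside the scatter. The only step beyond it is an at least 2.2-fold lower number from compound 2 to compound 4 (0.34 log units; beyond the scatter), and this is a floor set by the assay limit of compound 2: the limit of > 40000 nM in this assay, at which 1 of the 4 values shown sits.

On these data alone, whether an amine or ethoxy at this position would give a step beyond the scatter remains open. The same holds for a carboxylic acid in place of chloro on the 4-chlorophenyl group.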